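The source may hold more compounds than are shown below. What is called first, only, known or untested is meant among the compounds shown, and "the series" means these compounds.

Series notes. Compound 1 `O=C(NC1(C(=O)NO)CCN(Cc2ccccc2)CC1)c1ccc(C#Cc2ccccc2)cc1`, compound 2 `O=C(N[C@@H](CO)C(=O)NO)c1ccc(C#Cc2ccccc2)cc1` and compound 3 `O=C(CNC(=O)c1ccc(C#Cc2ccccc2)cc1)NO` share one core and differ only in the group carried on it. In a physicochemical assay for lipophilicity (a higher number here means a more lipophilic compound, a lower number a more polar compound), compound 1 gives > 3; this is a limit of the assay rather than a number, namely (the limit of > 3 in this assay, at which 1 of the 2 values shown sits). In this assay, within the data shown here, compound 2 gives 2, the only plain number in hand. Compound 3 has not yet been measured in this assay. Against compound 2 the change is hydrogen in place of hydroxymethyl on a saturated chain carbon bound to an amide-type nitrogen and a carbonyl carbon. Among the measured compounds shown here, no step between measured compounds is available, so the size of the step cannot be read from the data and has to be expected. The estimated a number 0.70 log units higher from compound 2 to compound 3 (beyond the scatter) is upward and beyond the usual scatter. Compound 3 is therefore expected to give 2.7 in this assay, the range running from 2.2 to 3.2.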

Compound 3, distribution coefficient: 3
Compound 3: middle estimate off by 0.30 log units, on the low side, within the range that was stated.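

On the saturated chain carbon bound to an amide-type nitrogen and a carbonyl carbon, hydrogen in place of hydroxymethyl now has a measured size: in this assay the change gives a number 1.00 log units higher from compound 2 to compound 3 (beyond the scatter). Among these compounds, this position therefore responds to the change in this assay, which the earlier compounds could not show, since they offered no step to read. Compound 1 gives > 3, a limit of the assay and not a number, so steps to it cannot be read: the limit of > 3 in this assay, at which 1 of the 3 values shown sits.

The shown compounds leave open how much of the step belongs to the carbon and how much to the oxygen of hydroxymethyl, a question that a methyl group on the same carbon would address. Also open, on these data alone, is whether an amine or a carboxylic acid on this carbon would move the read-out in the same direction.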